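Ring Nitrogen Methylation Across Two Ether-Linked Cores

The source may report more compounds than this note shows. Statements on the series, on what has been measured and on what is new or still open speak of the compounds shown alone.

Compound 3 `Oc1cncc(OC[C@@H]2CCCN2)c1` gives 2.5 nM in an assay on cell membranes for displacement of a labelled ligand from Neuronal acetylcholine receptor; alpha4/beta2 (Rattus norvegicus), read by scintillation counting; a higher number here means a weaker inhibitor, a lower number a stronger inhibitor. Compound 1 `CN1CCC[C@H]1COc1cncc(O)c1` carries methyl in place of hydrogen on an amine nitrogen in a ring and gives 3.7 nM; the step is a 1.5-fold higher number from compound 3 to compound 1 (0.17 log units; within the scatter). Compound 2 `c1ccc(OC[C@@H]2CCN2)cc1` has a core that differs from that of compound 3 in a way not broken down here; in this assay compound 2 gives 52 nM, the highest of the three measured numbers. Compound 4 `CN1CC[C@H]1COc1ccccc1` is not yet measured; against compound 2 it carries methyl in place of hydrogen on an amine nitrogen in a ring. This is the same kind of change as in compound 1, not the same: there the methyl sits on a five-membered non-aromatic ring with 1 nitrogen, next to the ring atom that bears a group of 9 heavy atoms, here on a four-membered ring, next to the ring atom that bears a group of 8 heavy atoms. Because a 1.5-fold higher number from compound 3 to compound 1 (0.17 log units; within the scatter) sits within the scatter, a similarly small step a 1.4-fold higher number from compound 2 to compound 4 (0.16 log units; within the scatter) is expected in this assay. Compound 4 is estimated at 75 nM, between 30 nM and 200 nM.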

Compound 4, inhibition constant: 101 nM
Compound 4: the middle estimate sits 1.3-fold (0.13 log units) below what was measured; the range from low to high includes it.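

In this assay, methyl in place of hydrogen on an amine nitrogen in a ring gives a 1.9-fold higher number from compound 2 to compound 4 (0.29 log units; within the scatter), and this step can be set beside the earlier one on the other core: the same change on two cores in this assay, a 1.5-fold higher number (0.17 log units; within the scatter) from compound 3 to compound 1 and a 1.9-fold higher number (0.29 log units; within the scatter) from compound 2 to compound 4, 1.3-fold (0.12 log units) apart, within the scatter of two such steps. On these two cores the change therefore carries over as a small step within the scatter, on the five-membered ring and on the four-membered ring alike. Two pairs do not show that the step stays this small on any further core, and they do not separate ring size from the rest of the core.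

The compounds shown leave open whether ethyl or a longer chain on the same ring nitrogen keeps the step this small. Going by these compounds, how the four-membered ring fares on the core of compound 3 also remains open.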